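One Aromatic Group Swapped in a Small Cytotoxicity Set

This account rests on a few compounds, and the source may have more. Where it says the series, first, only, none or still open, it means among the compounds named here.

Within the data shown here, in a functional assay on HepG2 cells (Homo sapiens) for cytotoxicity, read by MTT assay, with a stated time of 24 h (a higher number here means a weaker inhibitor, a lower number a stronger inhibitor), compound 1 `N#Cc1ccc(/C=C2\CN(S(=O)(=O)c3ccc(F)cc3)C/C(=C\c3ccc(C#N)cc3)C2=O)cc1` gives 11500 nM and stands at the high end of the three numbers known so far. Compound 2 `CC(=O)Nc1ccc(S(=O)(=O)N2C/C(=C\c3ccccc3F)C(=O)/C(=C/c3ccccc3F)C2)cc1` gives 5840 nM and lies within the scatter of compound 1, so the two share that high end. Compound 3 `CC(=O)Nc1ccc(S(=O)(=O)N2C/C(=C\c3ccc(C#N)cc3)C(=O)/C(=C/c3ccc(C#N)cc3)C2)cc1` gives 4880 nM and is the only one clearly apart. Putting acetamido in place of fluoro on an aromatic carbon gives a 2.4-fold lower number from compound 1 to compound 3 (0.37 log units; beyond the scatter) and this modest step concerns a different change from the one considered here.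

Compound 4 `N#Cc1ccc(/C=C2\CN(S(=O)(=O)c3ccc(F)cc3)C/C(=C\c3ccccc3F)C2=O)cc1` keeps that fluoro but carries 2-fluorophenyl in place of 4-cyanophenyl on a double-bonded chain carbon bound to a double-bonded ring carbon. Among the measured compounds shown here, no measured step covers this swap alone. The closest evidence is indirect: compound 2, with 2-fluorophenyl groups, at 5840 nM and compound 3, with 4-cyanophenyl groups, at 4880 nM lie within the scatter of each other. So in this assay the swap is expected to give no step beyond the scatter. The estimated change is a 1.0-fold lower number from compound 1 to compound 4 (0.02 log units; within the scatter) and it rests on that single pair. Compound 4 is expected at 11000 nM with an estimated range from 5500 nM to 22000 nM in this assay.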

Compound 4, half-maximal inhibitory concentration: 8180 nM
Compound 4: the middle estimate sits 1.3-fold (0.13 log units) above what was measured; the measured number falls inside the stated range.
By their numbers in this assay, from the lowest: compounds 3, 2, 4 and 1 (each within the scatter of the next, the first and the last beyond it).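

Among these compounds, this gives the first direct reading of the swap, with one 4-cyanophenyl group exchanged and the rest of the molecule held constant: in this assay, 2-fluorophenyl in place of 4-cyanophenyl gives a 1.4-fold lower number from compound 1 to compound 4 (0.15 log units; within the scatter). At this place, on a double-bonded chain carbon bound to a double-bonded ring carbon, the nitrile can therefore leave and a fluorine can enter the aromatic ring without a step beyond the usual scatter, at least while the second 4-cyanophenyl group stays on the shared core. No further measurement bears on this result, so nothing here can say what lies behind the small size of the step.

The compounds shown cover only two aromatic groups at this place, so it remains open whether the number would also hold with plain phenyl, with a ring carrying an amine such as dimethylamino, or with one carrying a carboxylic acid. As far as these compounds go, it is also open whether the same swap would give a similarly small step on a core carrying acetamido in place of fluoro, or if the second 4-cyanophenyl group were exchanged as well.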